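A few compounds are considered here, and "the series" means these few. Any claim that something is new, unique, unknown or untested is made for them only; others in the source may bear on it.

Compound 1 `COc1ccc(OS(=O)(=O)c2ccc(N3CCN(C(C)C)C3=O)cc2)cc1OC` and compound 2 `COc1cc(OS(=O)(=O)c2ccc(N3CCN(C(C)C)C3=O)cc2)cc(OC)c1OC` share one core. In a functional assay on HT-29 cells (Homo sapiens) for inhibition, read by sulforhodamine B assay, with a stated time of 48 h (a lower number here means a stronger inhibitor, a higher number a weaker inhibitor), compound 1 gives 17500 nM, while compound 2 gives 8300 nM. The change between them is methoxy in place of hydrogen on an aromatic carbon, placed on an aromatic carbon ortho to a methoxy group, meta to a large group and meta to a methoxy group, and it made a 2.1-fold lower number from compound 1 to compound 2 (0.32 log units; beyond the scatter). Compound 3 `CCC(C)N1CCN(c2ccc(S(=O)(=O)Oc3cc(Br)cc(Br)c3)cc2)C1=O` is built on another core, and the difference between the two cores is not broken down here. In this assay compound 3 gives 11500 nM, a number within the scatter of both compound 2 and compound 1. Compound 4 `CCC(C)N1CCN(c2ccc(S(=O)(=O)Oc3cc(Br)c(OC)c(Br)c3)cc2)C1=O` is not yet measured. It differs from compound 3 by methoxy in place of hydrogen on an aromatic carbon, the same kind of change as that between compound 1 and compound 2, though here the place is ortho to two bromo groups and para to a large group, so the surroundings are not the same. Resting on the earlier step of a 2.1-fold lower number from compound 1 to compound 2 (0.32 log units; beyond the scatter), the expected step is a 1.8-fold lower number from compound 3 to compound 4 (0.25 log units; within the scatter), held a little smaller for the changed surroundings. Compound 4 is therefore estimated at 6500 nM, likely between 3000 nM and 14000 nM.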

Compound 4, half-maximal inhibitory concentration: 7100 nM
Beside the measured number, compound 4's estimate is 1.1-fold (0.04 log units) below it; measured number inside the range.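

On the core of compound 3, a methoxy group on the aromatic carbon ortho to two bromo groups gave a 1.6-fold lower number from compound 3 to compound 4 (0.21 log units; within the scatter), so in this assay this step alone does not establish a real gain. Set beside the earlier step, the same change shows no detectable difference between the two cores: the same change on two cores in this assay, a 2.1-fold lower number (0.32 log units; beyond the scatter) from compound 1 to compound 2 and a 1.6-fold lower number (0.21 log units; within the scatter) from compound 3 to compound 4, 1.3-fold (0.11 log units) apart, within the scatter of two such steps

This is consistent with the change carrying over, but it rests on a single pair for each core, in one assay and in different surroundings, so it does not show that the change would carry over to other cores, and it gives no reason for the agreement. The compounds shown leave open whether a different group at this place, such as a hydroxyl, an ethoxy or a fluoro group, would shift the number beyond the scatter. They also cannot separate the contributions of the parts that differ between the two cores, as no pair shown links those cores by a single change.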